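Nitro and hydroxy variations on a chalcone sulfonylurea scaffold

The source may report more compounds than this note shows. Statements on the series, on what has been measured and on what is new or still open speak of the compounds shown alone.

Measured compounds:
compound 1, `Cc1ccc(S(=O)(=O)NC(=O)Nc2ccccc2C(=O)/C=C/c2ccccc2)cc1`: 25 ug/mL
compound 2, `CCOc1cc(/C=C/C(=O)c2ccccc2NC(=O)NS(=O)(=O)c2ccc(C)cc2)ccc1O`: 19.2 ug/mL
compound 3, `Cc1ccc(S(=O)(=O)NC(=O)Nc2ccccc2C(=O)/C=C/c2cccc([N+](=O)[O-])c2)cc1`: 44.5 ug/mL

In an ADME assay on the whole organism for cytotoxicity, with Artemia salina as the target, with a stated time of 24 h (on this read-out higher numbers stand for an effect only at larger amounts of compound and lower numbers for an effect already at smaller amounts), compound 3 gives 44.5 ug/mL, the highest of the three numbers; the step of a 1.8-fold higher number from compound 1 to compound 3 (0.25 log units; within the scatter) stays within the scatter, while a 2.3-fold higher number from compound 2 to compound 3 (0.37 log units; beyond the scatter) lies beyond it. Compound 4, `Cc1ccc(S(=O)(=O)NC(=O)Nc2ccccc2C(=O)/C=C/c2cc(O)ccc2[N+](=O)[O-])cc1`, differs from compound 3 by 5-hydroxy-2-nitrophenyl in place of 3-nitrophenyl on a double-bonded chain carbon bound to a double-bonded chain carbon. Going by the values given here, two measured steps bear on this: a 1.8-fold higher number from compound 1 to compound 3 (0.25 log units; within the scatter), and a 1.3-fold lower number from compound 1 to compound 2 (0.11 log units; within the scatter), where a hydroxy-bearing ring replaced plain phenyl. Both were small; the nitro remains in compound 4, and the added hydroxy resembles a change that moved the number little. No step beyond the scatter is therefore expected; compound 4 is estimated at 38 ug/mL, between 17 ug/mL and 85 ug/mL, a step of a 1.2-fold lower number from compound 3 to compound 4 (0.07 log units; within the scatter).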

Compound 4, concentration for half-maximal effect: 18.3 ug/mL
Beside the measured number, compound 4's estimate is 2.1-fold (0.32 log units) above it, and the stated range covers the measured number.
By their numbers in this assay, from the lowest: compounds 4, 2, 1 and 3 (each within the scatter of the next, the first and the last beyond it).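

In this assay, 5-hydroxy-2-nitrophenyl in place of 3-nitrophenyl on a double-bonded chain carbon bound to a double-bonded chain carbon gives a 2.4-fold lower number from compound 3 to compound 4 (0.39 log units; beyond the scatter) and so shows that a change confined to this ring can pass beyond the scatter. The steps of a 1.0-fold lower number from compound 2 to compound 4 (0.02 log units; within the scatter) and a 1.4-fold lower number from compound 1 to compound 4 (0.14 log units; within the scatter) stay within the scatter, so compound 4 cannot be told apart from compound 1 or compound 2. Nothing available accounts for the step from compound 3. The compounds shown leave open whether the added hydroxy or the changed place of the nitro matters, as both differ at once. They also leave open how an amine in place of the nitro would read.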